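The source may hold more compounds than are shown below. What is called first, only, known or untested is meant among the compounds shown, and "the series" means these compounds.

Measured so far, in a functional assay on SW480 cells (Homo sapiens) for cytotoxicity, read by MTT assay, with a stated time of 48 h; on this read-out higher numbers stand for weaker inhibition and lower numbers for stronger inhibition:
Compound 1, `Cc1cccc(Cn2cc(COc3ccc4c(=O)ccoc4c3)nn2)c1`, gives 11700 nM.
Compound 2, `N#Cc1ccc(Cn2cc(COc3ccc4c(=O)ccoc4c3)nn2)cc1`, gives > 100000 nM, which is a limit of the assay and not a number.
Compound 3, `O=c1ccoc2cc(OCc3cn(Cc4ccccc4Br)nn3)ccc12`, gives > 100000 nM, again a limit of the assay and not a number.

Compound 3 therefore stands at the weak end of what this series has shown: of the three values, two sit at the limit of > 100000 nM in this assay, at which 2 of the 3 values shown sit, and compound 3 is one of them. Going by the values given here, the only readable step that reaches it is an at least 8.5-fold higher number from compound 1 to compound 3 (0.93 log units; beyond the scatter), while a step that the two limits leave unreadable from compound 2 to compound 3.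

The next compound, compound 4, `O=c1ccoc2cc(OCc3cn(Cc4cccc(Br)c4)nn3)ccc12`, keeps every atom of compound 3 and only joins them differently: 3-bromophenyl in place of 2-bromophenyl on a saturated chain carbon bound to an aromatic nitrogen. Among the compounds with values here, no measured pair carries exactly this change. The nearest points of comparison are compound 1, which carries 3-methylphenyl at the same place and gives 11700 nM, and compound 3 itself. For compound 3 only a limit of the assay is known. Because compound 3 gives > 100000 nM, a step from it cannot be read in either direction, and the step of an at least 1.6-fold lower number from compound 3 to compound 4 (0.22 log units; that floor lies within the scatter) is only an expectation. Compound 4 is estimated at 60000 nM in this assay, within a range from 15000 nM to 150000 nM, with a fair chance that only a limit is returned.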

Compound 4, half-maximal inhibitory concentration: > 100000 nM
Compound 4 gave a limit, no number; the forecaster's own chance of this, stated with the estimate: 45%; middle value at least 1.6-fold (0.22 log units) away from the limit.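

With the ring position now matched, compound 1 and compound 4 differ only by bromo in place of methyl on an aromatic carbon, and in this assay that single exchange gives an at least 8.5-fold higher number from compound 1 to compound 4 (0.93 log units; beyond the scatter). The 3-position therefore does not by itself return a number, since 3-bromophenyl ends at a limit just as 2-bromophenyl and 4-cyanophenyl do, and among the compounds shown only the 3-methylphenyl of compound 1 gives a number. The steps from compound 3 to compound 4 and from compound 2 to compound 4 cannot be read, as both ends of each are limits, so the two bromophenyl groups cannot be ranked, and the limit now holds most of the series: the limit of > 100000 nM in this assay, at which 3 of the 4 values shown sit.

The compounds shown leave open whether the measurable value of compound 1 belongs to methyl alone, or whether a methoxy group or an amine in the same place on the phenyl ring would also return a number. They also leave open how far compound 2, compound 3 and compound 4 differ from one another, as none of the three has a value that can be compared.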